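Where the Chlorine Sits: From Compound 2 to Compound 3

The source may hold more compounds than are shown below. What is called first, only, known or untested is meant among the compounds shown, and "the series" means these compounds.

Of the compounds shown here, two have so far been measured in a functional assay on A549 cells (Homo sapiens) for antiproliferative activity, read by MTT assay, with a stated time of 72 h; on this read-out lower numbers stand for stronger inhibition and higher numbers for weaker inhibition. Compound 1 `S=C(Sc1ccccc1)N1CCCCC1` gives 7930 nM in this assay. Compound 2 `CC(C)(C)OC(=O)N1CCN(C(=S)Sc2ccc(Cl)cc2)CC1` gives 1070 nM in this assay. Of these two numbers, compound 2 stands lowest; its nearest neighbour is compound 1, and the gap between them lies beyond the usual scatter of the assay. Going by the values given here, no two measured compounds differ in only one place, so the size of any single structural step in this assay is not yet known.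

Compound 3 `CC(C)(C)OC(=O)N1CCN(C(=S)Sc2ccccc2Cl)CC1` has not been measured. It differs from compound 2 in one respect: 2-chlorophenyl in place of 4-chlorophenyl on a sulfur. The two compounds share every atom and differ only in how those atoms are joined. Among the compounds with values here, with no measured step of this kind to lean on, the change in this assay is expected to be small, in either direction, and quite possibly none beyond the scatter. Compound 3 is therefore expected to give about 1500 nM in this assay, within a range from 500 nM to 5000 nM. The step from compound 2 to compound 3 is estimated at a 1.4-fold higher number from compound 2 to compound 3 (0.15 log units; within the scatter).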

Compound 3, half-maximal inhibitory concentration: 1560 nM
Compound 3: the middle estimate sits 1.0-fold (0.02 log units) below what was measured, and the stated range covers the measured number.
By their numbers in this assay, from the lowest: compounds 2 and 3 (each within the scatter of the next); then compound 1.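

In this assay, going by these compounds alone, the first step between compounds that differ in only one place now has a size: 2-chlorophenyl in place of 4-chlorophenyl on a sulfur gives a 1.5-fold higher number from compound 2 to compound 3 (0.16 log units; within the scatter). For this pair, then, where the chlorine stands on the phenyl ring does not separate the two numbers, something compounds 1 and 2 could not show, as they differ in more than one place. No measurement at hand bears on why the two numbers lie this close, so the result stands as a plain observation.

The compounds shown leave open what the chlorine itself contributes, and whether a methoxy group, a nitro group or a fluorine in its place on the phenyl ring would leave the number within the scatter as well. They also leave open what happens when the tert-butoxycarbonyl group on the shared core gives way to a free amine or an acetyl group, and whether the step between the two chlorophenyl groups would stay this small in that setting.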